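The source may hold more compounds than are shown below. What is called first, only, known or untested is meant among the compounds shown, and "the series" means these compounds.

Three compounds share one core and differ in two places. Compound 1 `Cc1nc(-c2ccccc2)c(C(=O)N2CCN(c3cccc(C#N)c3)CC2)o1` gives 1.6% in an ADME assay on microsomes from liver (Mus musculus) for metabolic stability, read by LC-MS, with a stated time of 1 h, tested at 5 uM; a lower number here means that less of the compound is left, a higher number that more of the compound is left. Compound 2 `Cc1nc(-c2ccc(F)cc2)c(C(=O)N2CCN(c3cc(Cl)cc(Cl)c3)CC2)o1` gives 31.1%, and compound 3 `Cc1nc(-c2ccccc2)c(C(=O)N2CCN(c3cc(Cl)cc(Cl)c3)CC2)o1` gives 43.4%, the highest of the three numbers. The step of a number 41.8 percentage points higher from compound 1 to compound 3 (beyond the scatter) was large, while the step of a number 12.3 percentage points higher from compound 2 to compound 3 (beyond the scatter) was modest. Compound 4 `Cc1nc(-c2ccccc2)c(C(=O)N2CCN(c3cccc(Cl)c3)CC2)o1` differs from compound 3 by hydrogen in place of chloro on an aromatic carbon. Among the measured compounds shown here, only the step of a number 41.8 percentage points higher from compound 1 to compound 3 (beyond the scatter) bears on the same part of the molecule, and it shows that changing the group on the amine nitrogen moved the number a long way, so taking one chloro away is expected to lower it by a step of a number 23.4 percentage points lower from compound 3 to compound 4 (beyond the scatter). Compound 4 is therefore estimated at 20%, within a range from 5% to 40%.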

Compound 4, percent of the compound remaining: 2%
Compound 4: the middle estimate sits 18 percentage points above what was measured; measured number below the stated range.
By their numbers in this assay, from the lowest: compounds 1 and 4 (each within the scatter of the next); then compound 2; then compound 3.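

In this assay, the second chloro of the 3,5-dichlorophenyl group matters greatly: hydrogen in its place gives a number 41.4 percentage points lower from compound 3 to compound 4 (beyond the scatter). Chloro in place of cyano gives a number 0.4 percentage points higher from compound 1 to compound 4 (within the scatter), so with a single group on this ring, these two cannot be told apart. Only the ring with both chloro groups stands clear of them, and no measurement here explains why. Going by these compounds, whether a methoxy or trifluoromethyl group could take the place of the second chloro and keep the number high remains open.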